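Fluoro on the Aromatic Carbon of Compound 1

The compounds below may be only part of what the source reports. "The series", "measured", "known", "first", "only" and "open" are said of these compounds alone.

Measured in a physicochemical assay for acid dissociation:
- Compound 1 `NS(=O)(=O)c1ccc(S(=O)(=O)CCCO)cc1`: 8.98
- Compound 2 `NS(=O)(=O)c1ccc(S(=O)(=O)CC(O)CO)cc1`: 9.35

Of these two compounds, compound 1 has the lower number, 8.98, against compound 2 at 9.35. Compound 3 `NS(=O)(=O)c1ccc(S(=O)(=O)CCCO)c(F)c1` has not yet been measured in this assay. It differs from compound 1 by one change, (fluoro in place of hydrogen on an aromatic carbon), which is fluoro in place of hydrogen on an aromatic carbon.

Among the measured compounds shown here, only one measured step is available: a number 0.37 log units higher from compound 1 to compound 2 (beyond the scatter). That modest step lies beyond the scatter, but it concerns a saturated chain carbon and not an aromatic carbon, so it serves only as a rough guide to size. For the measured compounds named here, no measured step shows what a fluoro group does here, which leaves the direction a matter of judgement. A lower number is expected, with the estimated change being a number 0.38 log units lower from compound 1 to compound 3 (beyond the scatter). For compound 3 the expected value is 8.6, with an estimated range from 8.25 to 8.95.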

Compound 3, acid dissociation constant: 9.02
Estimate against measurement, compound 3: 0.42 log units below, outside the stated range (above it).
By their numbers in this assay, from the lowest: compounds 1 and 3 (each within the scatter of the next); then compound 2.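

In this assay, fluoro in place of hydrogen on an aromatic carbon, ortho to a group of 7 heavy atoms and meta to a sulfamoyl group, gives a number 0.04 log units higher from compound 1 to compound 3 (within the scatter), so the two compounds cannot be told apart in this read-out. Among the compounds shown here, the earlier pair showed only a change on a saturated chain carbon, a number 0.37 log units higher from compound 1 to compound 2 (beyond the scatter), whereas this result gives the first reading at an aromatic carbon of the core, and at this position the single fluoro group leaves the two numbers within the scatter of each other. Nothing among the data shown accounts for this result.

The compounds shown place only fluoro at this aromatic carbon, so it remains open whether chloro, methoxy or a nitrile at the same place would also stay within the scatter of compound 1. Also open, as far as these compounds go, is whether fluoro on another aromatic carbon of the ring, or the same fluoro combined with the added hydroxy of compound 2, would give a similar reading.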